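Hydrogen for methyl on an oxygen: compound 2 to compound 4

The source may report more compounds than this note shows. Statements on the series, on what has been measured and on what is new or still open speak of the compounds shown alone.

Compound 2 `CC/C(=N/OC)c1ccc2oc(CSc3nnc(CNc4ccccc4)n3CC)nc2c1` is the weaker of the two compounds with a result. In an assay on isolated protein for inhibition of long-chain fatty acid transport protein 1 (Mus musculus) (on this read-out higher numbers stand for weaker inhibition and lower numbers for stronger inhibition), compound 2 gives only a limit, > 10000 nM, and not a number. This is the limit of > 10000 nM in this assay, at which 1 of the 3 values shown sits. Compound 3 `CCC(=O)c1ccc2nc(CSc3nnc(CNc4ccccc4)n3CC)oc2c1`, which carries a carbonyl in place of the methoxy-bearing double-bonded nitrogen, gives 1200 nM in this assay. Compound 1 `CCn1c(CNc2ccccc2)nnc1SCC(=O)Nc1ccc(C(C)=O)cc1` has "not determined" (no result reported) in this assay, so it adds nothing to the comparison.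

Compound 4 `CC/C(=N/O)c1ccc2oc(CSc3nnc(CNc4ccccc4)n3CC)nc2c1` differs from compound 2 in a single place: hydrogen in place of methyl on an oxygen. Among the measured compounds shown here, no measured pair with this change exists, so the size of the step is open. The expectation is for a moderate step toward stronger inhibition, beyond the usual scatter but short of the value of compound 3, since the shared core with a carbonyl in compound 3 reaches 1200 nM in this assay. The expected step is an at least 2.0-fold lower number from compound 2 to compound 4 (0.30 log units; that floor lies within the scatter). Compound 4 is estimated at 5000 nM, with a range from 1500 nM to 20000 nM.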

Compound 4, half-maximal inhibitory concentration: 200 nM
Estimate against measurement, compound 4: 25-fold (1.40 log units) above, outside the stated range (below it).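

On an oxygen whose other neighbour is the double-bonded nitrogen, methoxy to hydroxy gives an at least 50-fold lower number from compound 2 to compound 4 (1.69 log units; beyond the scatter) in this assay, so inhibition in this series responds strongly to what this oxygen carries. Among the compounds shown here, the earlier compounds offered no measured pair differing in a single place, which makes this the first single change that can be read. Compound 2 has a limit and not a number, so the full size of the step remains unknown: the limit of > 10000 nM in this assay, at which 1 of the 4 values shown sits.

A single pair cannot tell whether the step depends on losing the methyl or on gaining the hydrogen. With only methyl and hydrogen shown on this oxygen, the effect of an ethyl group, a longer chain or an amine at this place remains open.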